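Ester for Nitrile on a Shared Indazole-Type Core

The compounds below may be only part of what the source reports. "The series", "measured", "known", "first", "only" and "open" are said of these compounds alone.

Compound 2 `N#Cc1cc(NCc2ccccc2[N+](=O)[O-])c2cn[nH]c2c1` carries a cyano group on its core. In an assay for inhibition of Indoleamine 2,3-dioxygenase 1 (Homo sapiens), with stated times of 10 min and 60 min (a higher number here means a weaker inhibitor, a lower number a stronger inhibitor), compound 2 gives only a limit, > 100000 nM, and not a number. This is the case described by the limit of > 100000 nM in this assay, at which 1 of the 3 values shown sits. Compound 3 `O=[N+]([O-])c1ccc(CNc2cc(Br)cc3[nH]ncc23)cc1`, which carries a bromo substituent instead, gives 6970 nM in this assay. For compound 1 `O=[N+]([O-])c1ccccc1CNc1cccc2[nH]ncc12` no result is reported ("nd" (no result reported)). Compound 4 `COC(=O)c1cc(NCc2ccccc2[N+](=O)[O-])c2cn[nH]c2c1` differs from compound 2 by methoxycarbonyl in place of cyano on an aromatic carbon. Because compound 2 sits at a limit, no measured step sizes this change. Compound 4 is expected to stay a weak inhibitor, the expected step being an at least 1.6-fold lower number from compound 2 to compound 4 (0.22 log units; that floor lies within the scatter). The estimated half-maximal inhibitory concentration of compound 4 is 60000 nM, between 15000 nM and 300000 nM.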

Compound 4, half-maximal inhibitory concentration: > 100000 nM
Compound 4 gave a limit, no number; the forecaster's own chance of this, stated with the estimate: 55%; middle value at least 1.6-fold (0.22 log units) away from the limit.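

Within the data shown here, compound 2 and compound 4 both give only limits in this assay, so no step between them can be read. The compounds shown leave open how methoxycarbonyl and cyano compare on the shared core.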